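The source may report more compounds than this note shows. Statements on the series, on what has been measured and on what is new or still open speak of the compounds shown alone.

Compound 1 `O=C1NC(=O)/C(=C/C2=Cc3ccccc3OC2)S1` is the weaker of the two compounds measured here: in a functional assay on MOLT-4 cells (Homo sapiens) for antiproliferative activity, read by MTT assay, with a stated time of 72 h (a higher number here means a weaker inhibitor, a lower number a stronger inhibitor), compound 1 gives 101000 nM, whereas compound 2 `O=C1NC(=O)/C(=C/C2=Cc3ccccc3OC2)N1` gives 21300 nM in this assay, a gap beyond the scatter. Compound 3 `CCN1C(=O)S/C(=C\C2=Cc3ccccc3OC2)C1=O` differs from compound 1 by ethyl in place of hydrogen on an amide-type nitrogen in a ring. Going by the values given here, no comparable step has been measured in this set, so the direction of this change is uncertain; a step from compound 1 to compound 3 of a 1.2-fold higher number from compound 1 to compound 3 (0.07 log units; within the scatter) is expected, likely within the scatter. Compound 3 is therefore estimated at 120000 nM in this assay, with a range from 40000 nM to 350000 nM.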

Compound 3, half-maximal inhibitory concentration: > 200000 nM
Compound 3: a limit, no number (the forecaster's own chance of this, stated with the estimate: 20%); at least 1.6-fold (0.22 log units) between middle value and limit.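

In this assay, the result for compound 3 is a limit of the assay, not a number: the limit of > 200000 nM in this assay, at which 1 of the 3 values shown sits.

This gives the first view of a substituent on the amide-type nitrogen in a ring, and ethyl in place of hydrogen gives an at least 1.9-fold higher number from compound 1 to compound 3 (0.29 log units; that floor lies within the scatter). Going by these compounds, the true size of the step remains unknown, but ethyl here brought no measurable gain over the amide hydrogen.

On these data alone, whether methyl, a longer chain such as propyl, or a chain ending in an amine or a carboxylic acid would behave the same way remains open. So does the effect of ethyl on compound 2.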